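This account rests on a few compounds, and the source may have more. Where it says the series, first, only, none or still open, it means among the compounds named here.

Measured compounds:
Compound 1, `CCCc1cc2cc(Cl)cc(Cn3nc(C(=O)O)cc3C)c2o1`, in an assay on CHO-K1 cells for displacement of a labelled ligand from prostaglandin E2 receptor EP1 subtype (Homo sapiens), read by scintillation counting, with a stated time of 45 min (a higher number here means a weaker inhibitor, a lower number a stronger inhibitor), compound 1 gives 25.1 nM.
Compound 2, `Cc1cc(C(=O)O)nn1Cc1cc(Cl)cn2nc(C(C)C)cc12`, is reported in this assay only as the limit > 1000 nM, which is a boundary of the measurement and not a number.
Compound 3, `Cc1cc(C(N)=O)nn1Cc1cc(Cl)cc2cc(-c3ccccc3)oc12`, in this assay compound 3 gives 5.01 nM.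

Among the two numbers, compound 3 holds the lower one; compound 1, its nearest neighbour, sits higher by a gap beyond the usual scatter. Compound 2 contributes only a limit, at which one of the three values rests (the limit of > 1000 nM in this assay, at which 1 of the 3 values shown sits).

Compound 4, `Cc1cc(NC(=O)C2(F)CCNCC2)nn1Cc1cc(Cl)cc2cc(-c3ccccc3)oc12`, has not been measured. It differs from compound 3 in one place: ((4-fluoropiperidin-4-yl)carbonyl)amino in place of carbamoyl on an aromatic carbon. Going by the values given here, no pair of measured compounds shows this change, so there is no measured step to lean on, and the grounds for an expectation are thin. The carbamoyl group stands in the compound with the lowest number, and replacing it with a much larger group is judged more likely to weaken than to strengthen binding, so a step of modest size toward a higher number is expected from compound 3 to compound 4, a 4.0-fold higher number from compound 3 to compound 4 (0.60 log units; beyond the scatter). For compound 4 the expected value in this assay is 20 nM, within a range from 3 nM to 200 nM.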

Compound 4, half-maximal inhibitory concentration: 39.8 nM
Beside the measured number, compound 4's estimate is 2.0-fold (0.30 log units) below it; low and high end bracket the measured number.
By their numbers in this assay, from the lowest: compound 3; then compounds 1 and 4 (each within the scatter of the next). At a limit, above all of these: compound 2.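

In this assay, the change gives the first step read at this position: putting ((4-fluoropiperidin-4-yl)carbonyl)amino in place of carbamoyl on this aromatic carbon gives a 7.9-fold higher number from compound 3 to compound 4 (0.90 log units; beyond the scatter). This modest step shows that the position accepts a far larger group carrying a non-aromatic ring, at a measurable cost in the number but without reaching a limit. No evidence shown here bears on what sets the size of this step.

The compounds shown leave open which part of the new group accounts for the step: the ring, its fluorine or the amide link. A plain acetylamino group or a piperidin-4-yl carbonylamino group without fluorine on this carbon would separate these, and a carboxylic acid there would show how that group compares with carbamoyl on this core.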